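Replacing Phenyl with 3,4-Dimethoxyphenyl on Compound 1

The compounds below may be only part of what the source reports. "The series", "measured", "known", "first", "only" and "open" are said of these compounds alone.

In an ADME assay on Vero cells (Chlorocebus sabaeus) for inhibition, read by sulforhodamine B assay, with a stated time of 48 h (a higher number here means a weaker inhibitor of growth, a lower number a stronger inhibitor of growth), compound 1 (`O=C(NNC(=O)c1ccc2[nH]c(-c3ccc([N+](=O)[O-])o3)nc2c1)c1ccccc1`) gives 31.3 ug/mL, and compound 2 (`O=C(NNC(=O)c1cc2ccccc2cc1O)c1ccc2[nH]c(-c3ccc([N+](=O)[O-])s3)nc2c1`) gives 31.3 ug/mL, so the two stand level. Compound 3 (`COc1ccc(C(=O)NNC(=O)c2ccc3[nH]c(-c4ccc([N+](=O)[O-])o4)nc3c2)cc1OC`) carries 3,4-dimethoxyphenyl in place of phenyl on a carbonyl carbon. Going by the values given here, no measured pair shows what a change of this kind does in this assay, so no shift beyond the scatter is expected, in either direction. The expected move is no change at the digits printed from compound 1 to compound 3 (within the scatter). Compound 3 is estimated at 31.3 ug/mL, with an expected range from 12 ug/mL to 90 ug/mL.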

Compound 3, concentration for 50% growth inhibition: 62.5 ug/mL
For compound 3 the middle estimate is 2.0-fold (0.30 log units) below the measured one; low and high end bracket the measured number.
By their numbers in this assay, from the lowest: compounds 1, 2 and 3 (each within the scatter of the next).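

In this assay 3,4-dimethoxyphenyl in place of phenyl on a carbonyl carbon gives a 2.0-fold higher number from compound 1 to compound 3 (0.30 log units; within the scatter) as the first step read at this position. It shows that this larger aromatic group, which brings hydrogen-bond acceptors that phenyl lacks, is taken up here without a shift beyond the scatter. Nothing measured here accounts for the step. On these data alone, whether an amine or a carboxylic acid on this phenyl would shift the number stays open. So does the effect of a longer chain in its place.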